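The source may hold more compounds than are shown below. What is called first, only, known or untested is meant among the compounds shown, and "the series" means these compounds.

Within the data shown here, compound 2 `CC(=O)NS(=O)(=O)c1ccc(-n2nc(-c3ccccc3)cc2-c2cc(O)ccc2O)cc1` gives 78100 nM in a functional assay on cells (Cancer cell lines, Homo sapiens) for cytotoxicity, read by sulforhodamine B assay, with a stated time of 48 h (on this read-out lower numbers stand for stronger inhibition of growth and higher numbers for weaker inhibition of growth), the highest of the two numbers measured so far. Compound 1 `NS(=O)(=O)c1ccc(-n2nc(-c3ccc(Cl)cc3)cc2-c2cc(O)ccc2O)cc1` gives 12000 nM in this assay, and since compound 1 and compound 2 differ in two places at once, no single step can be read from that pair. Compound 3 `CC(=O)NS(=O)(=O)c1ccc(-n2nc(-c3ccc(Cl)cc3)cc2-c2cc(O)ccc2O)cc1` differs from compound 2 by chloro in place of hydrogen on an aromatic carbon. A moderate step toward stronger inhibition of growth is expected here, of the size a 2.6-fold lower number from compound 2 to compound 3 (0.42 log units; beyond the scatter), but this rests on thin evidence. Compound 3 is therefore estimated at 30000 nM, within a range from 10000 nM to 90000 nM.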

Compound 3, concentration for 50% growth inhibition: 23500 nM
Compound 3: middle estimate off by 1.3-fold (0.11 log units), on the high side; measured number inside the range.
By their numbers in this assay, from the lowest: compounds 1 and 3 (each within the scatter of the next); then compound 2.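

On the phenyl group, chloro in place of hydrogen, para to a large group, gives a 3.3-fold lower number from compound 2 to compound 3 (0.52 log units; beyond the scatter) in this assay, the first single change seen to shift growth inhibition. Acetyl in place of hydrogen on the sulfonamide nitrogen gives a 2.0-fold higher number from compound 1 to compound 3 (0.29 log units; within the scatter), so with chloro present the two forms cannot be told apart. No measurement at hand explains either result. As far as these compounds go, whether fluoro, methoxy or an amine at that ring position would act like chloro remains open. So does whether a longer acyl chain on the sulfonamide nitrogen would match acetyl.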